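The compounds below may be only part of what the source reports. "The series", "measured", "known", "first", "only" and "open" are said of these compounds alone.

Working notes on the series. The shared core is that of compound 1 `Cc1ccc(C(=O)N/N=C/c2ccccc2)c(O)c1`, which in a functional assay (Mus musculus, strain BALB/C) for inhibition, read by MTT assay, with stated times of 24 h and 72 h (a lower number here means a stronger inhibitor, a higher number a weaker inhibitor), gives 53900 nM. Compound 2 `Cc1ccc(C(=O)N/N=C/c2ccc(Cl)cc2)c(O)c1` gives 12300 nM in this assay, the step being a 4.4-fold lower number from compound 1 to compound 2 (0.64 log units; beyond the scatter). For compound 3 `Cc1ccc(C(=O)N/N=C/c2ccc(N(C)C)cc2)c(O)c1` this assay reports > 100000 nM, a limit of the assay and not a number (the limit of > 100000 nM in this assay, at which 1 of the 3 values shown sits). Compound 3 thus stands at the weak end of the three values shown, with an at least 8.1-fold higher number from compound 2 to compound 3 (0.91 log units; beyond the scatter) and an at least 1.8-fold higher number from compound 1 to compound 3 (0.26 log units; that floor lies within the scatter). Compound 4 `Cc1ccc(C(=O)N/N=C/c2ccc(F)cc2)c(O)c1` differs from compound 3 by fluoro in place of dimethylamino on an aromatic carbon. The step from compound 2 to compound 3 bears on this change in reverse, and the chloro step from compound 1 to compound 2 suggests a halogen on this aromatic carbon lowers the number. Compound 4 is therefore expected near 30000 nM, between 8000 nM and 100000 nM, an expected step of an at least 3.3-fold lower number from compound 3 to compound 4 (0.52 log units; beyond the scatter).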

Compound 4, half-maximal inhibitory concentration: 26700 nM
Beside the measured number, compound 4's estimate is 1.1-fold (0.05 log units) above it; the range from low to high includes it.
By their numbers in this assay, from the lowest: compound 2; then compound 4; then compound 1. At a limit, above all of these: compound 3.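

Fluoro in place of hydrogen gives a 2.0-fold lower number from compound 1 to compound 4 (0.31 log units; beyond the scatter), so the lowering seen with chloro on this aromatic carbon is not confined to one halogen. The two halogens are not equivalent in this assay: fluoro in place of chloro gives a 2.2-fold higher number from compound 2 to compound 4 (0.34 log units; beyond the scatter). Compound 3 stands at a limit of the assay, so an at least 3.7-fold lower number from compound 3 to compound 4 (0.57 log units; beyond the scatter) is only a floor for the change from dimethylamino to fluoro.

As far as these compounds go, whether bromo, methoxy or a carboxylic acid on this aromatic carbon would follow the halogens stays open. From the compounds shown here alone, how the series responds to changes elsewhere on the shared core also stays open.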